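Swapping a Bromophenyl for an Aminophenyl Amine

The source may report more compounds than this note shows. Statements on the series, on what has been measured and on what is new or still open speak of the compounds shown alone.

Compound 3 `Fc1cccc(-c2nc(Nc3cccc(Br)c3)c3cc(F)ccc3n2)c1` stands at a limit rather than a number: in a functional assay on MDA-MB-231 cells (Homo sapiens) for cytotoxicity, read by MTT assay, with a stated time of 48 h (on this read-out higher numbers stand for weaker inhibition and lower numbers for stronger inhibition), compound 3 gives > 50000 nM, which is the limit of > 50000 nM in this assay, at which 1 of the 3 values shown sits. Compound 1 `Fc1cccc(-c2nc(Nc3ccccc3)c3cc(F)ccc3n2)c1` gives 47800 nM in this assay, and compound 2 `COc1ccc(Nc2nc(-c3cccc(F)c3)nc3ccc(F)cc23)cc1` gives 47300 nM. The step of a 1.0-fold lower number from compound 1 to compound 2 (0.00 log units; within the scatter) and the step of an at least 1.0-fold higher number from compound 1 to compound 3 (0.01 log units; that floor lies within the scatter) both stay within the scatter, as does an at least 1.0-fold higher number from compound 2 to compound 3 (0.02 log units; that floor lies within the scatter). Compound 4 `Nc1ccccc1Nc1nc(-c2cccc(F)c2)nc2ccc(F)cc12` differs from compound 3 by 2-aminophenyl in place of 3-bromophenyl on a nitrogen on an aromatic ring. For the measured compounds named here, none of the measured steps involves an amino group, so they give no ground for a shift in either direction; from three flat steps a change beyond the scatter is not expected. Compound 4 is therefore estimated at 50000 nM, with a range from 20000 nM to 120000 nM, which means an expected step of a number no higher from compound 3 to compound 4 (the limit leaves the size open).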

Compound 4, half-maximal inhibitory concentration: > 50000 nM
Compound 4: a limit, no number (the forecaster's own chance of this, stated with the estimate: 50%); the middle value lies on the limit itself.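

Compound 4 also ends at a limit and not a number, so the step from compound 3 cannot be read: the limit of > 50000 nM in this assay, at which 2 of the 4 values shown sit.

For the compounds shown here, the two readable steps, an at least 1.0-fold higher number from compound 2 to compound 4 (0.02 log units; that floor lies within the scatter) and an at least 1.0-fold higher number from compound 1 to compound 4 (0.01 log units; that floor lies within the scatter), show that an amino group on this ring, absent from the earlier compounds, gives no sign of stronger inhibition.

Still open is whether another group on this ring, such as a carboxylic acid or a dimethylamino group, would give a value clearly beyond the scatter of these compounds.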